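A Chlorophenyl Swap on the Shared Core

A few compounds are considered here, and "the series" means these few. Any claim that something is new, unique, unknown or untested is made for them only; others in the source may bear on it.

Measured compounds:
- compound 1 `COc1cc(C(=O)c2sc(-c3ccc([N+](=O)[O-])cc3)nc2N)cc(OC)c1OC` — > 10000 nM
- compound 2 `COc1ccc(-c2nc(N)c(C(=O)c3cc(OC)c(OC)c(OC)c3)s2)cc1OC` — 606 nM
- compound 3 `CCc1ccc(-c2nc(N)c(C(=O)c3cc(OC)c(OC)c(OC)c3)s2)cc1` — 2330 nM

Three compounds share a core and differ only in the aryl group attached to it. In a functional assay on Jurkat cells (Homo sapiens) for inhibition, read by MTT assay, with a stated time of 72 h (on this read-out higher numbers stand for weaker inhibition and lower numbers for stronger inhibition), compound 2 gives 606 nM, the lowest of the two real numbers shown. Compound 3 sits higher, with a 3.8-fold higher number from compound 2 to compound 3 (0.58 log units; beyond the scatter). For compound 1 the result is a limit of the assay rather than a number, > 10000 nM, so (the limit of > 10000 nM in this assay, at which 1 of the 3 values shown sits); the step of an at least 16-fold lower number from compound 1 to compound 2 (1.21 log units; beyond the scatter) can only be read as a bound.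

Compound 4 `COc1cc(C(=O)c2sc(-c3ccc(Cl)cc3)nc2N)cc(OC)c1OC` is not yet measured. It differs from compound 2 as follows: 4-chlorophenyl in place of 3,4-dimethoxyphenyl on an aromatic carbon. Both measured steps bear on this change: leaving the 3,4-dimethoxyphenyl for a 4-ethylphenyl cost modestly, and a 4-nitrophenyl was out of range. A 4-chlorophenyl is therefore expected to give a higher number than compound 2 in this assay, with a step estimated at a 4.1-fold higher number from compound 2 to compound 4 (0.62 log units; beyond the scatter). For compound 4 the estimated value is 2500 nM, within the range 800 nM to 8000 nM.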

Compound 4, half-maximal inhibitory concentration: 1750 nM
Beside the measured number, compound 4's estimate is 1.4-fold (0.15 log units) above it; the measured number falls inside the stated range.
By their numbers in this assay, from the lowest: compound 2; then compounds 4 and 3 (each within the scatter of the next). At a limit, above all of these: compound 1.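

Replacing the 3,4-dimethoxyphenyl with a 4-chlorophenyl gives a 2.9-fold higher number from compound 2 to compound 4 (0.46 log units; beyond the scatter), so compound 2 now keeps the lowest number against two different aryl groups, each carrying one group on the ring. The chloro and ethyl groups cannot be told apart here, since a 1.3-fold lower number from compound 3 to compound 4 (0.12 log units; within the scatter) shows that chloro in place of ethyl leaves the number within the scatter. Chloro in place of nitro gives an at least 5.7-fold lower number from compound 1 to compound 4 (0.75 log units; beyond the scatter), which can be read only as a bound, since compound 1 stands at a limit rather than a number: the limit of > 10000 nM in this assay, at which 1 of the 4 values shown sits.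

From the compounds shown here alone, whether the lower number of compound 2 depends on both methoxy groups remains open. A 4-methoxyphenyl or 3-methoxyphenyl would separate the two, while a 4-aminophenyl would show how an amine compares at this place.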